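The compounds below may be only part of what the source reports. "The series", "measured", "known", "first", "only" and "open" are said of these compounds alone.

Series notes. Going by the values given here, compound 2 `CC(C(=O)NCc1ccc(Cl)c(Cl)c1)c1ccc(NS(C)(=O)=O)c(F)c1` holds the lower of the two numbers so far: in an assay on CHO cells for displacement of a labelled ligand from transient receptor potential cation channel subfamily V member 1 (Rattus norvegicus) (on this read-out higher numbers stand for weaker inhibition and lower numbers for stronger inhibition), compound 2 gives 200 nM, while compound 1 `CC(C)(C)c1ccc(CNC(=O)C(C)(C)c2ccc(NS(C)(=O)=O)c(F)c2)cc1` gives 1070 nM, a gap beyond the scatter. Compound 3 `CC(C(=O)NCc1ccc(C2CC2)cc1)c1ccc(NS(C)(=O)=O)c(F)c1` is not yet measured; it differs from compound 2 by 4-cyclopropylphenyl in place of 3,4-dichlorophenyl on a saturated chain carbon bound to an amide-type nitrogen. Among the compounds with values here, no measured pair shows this exchange, so the size of the step in this assay is open; a modest weakening is expected, though a step within the scatter would not surprise. For compound 3 the expected value in this assay is 400 nM, within 100 nM to 1500 nM. The step this implies, a 2.0-fold higher number from compound 2 to compound 3 (0.30 log units; within the scatter), is an expectation only.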

Compound 3, inhibition constant: 411 nM
The estimate for compound 3 lay 1.0-fold (0.01 log units) below the measured number; measured number inside the range.
By their numbers in this assay, from the lowest: compound 2; then compound 3; then compound 1.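

Going by these compounds alone, exchanging 3,4-dichlorophenyl for 4-cyclopropylphenyl on a saturated chain carbon bound to an amide-type nitrogen gives in this assay the first readable step: a 2.1-fold higher number from compound 2 to compound 3 (0.31 log units; beyond the scatter) and so a modest weakening. Binding at this position therefore survives the loss of both chlorines when an all-carbon group enters, at a modest cost. Nothing measured here bears on the cause of this step.

On these data alone, whether a 4-trifluoromethylphenyl or a 4-methoxyphenyl group at this place would give a lower number stays open. So does whether the step keeps its size on other cores.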